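Working notes: stomach assay, compounds 1 to 3

The source may hold more compounds than are shown below. What is called first, only, known or untested is meant among the compounds shown, and "the series" means these compounds.

Measured so far:
compound 1 `N#CNC(=N)NCCCCCn1nc(-c2ccccc2)ccc1=O`: > 100 mg/kg
compound 2 `C=CCNC(=S)NCCCCn1nc(-c2ccccc2)ccc1=O`: > 100 mg/kg

In a functional assay on the whole organism (stomach) with Rattus norvegicus as the target (a lower number here means that less compound is needed, a higher number that more compound is needed for the effect), compound 1 gives > 100 mg/kg, a limit of the assay rather than a number. In this assay compound 2 gives > 100 mg/kg, likewise a limit. Compound 2 therefore stands at the limit of > 100 mg/kg in this assay, at which 2 of the 2 values shown sit. Within the data shown here, the single measured step, a step that the two limits leave unreadable from compound 1 to compound 2, is unreadable. Compound 3 `CC/N=C(\S)NCCCCn1nc(-c2ccccc2)ccc1=O` differs from compound 2 by a group of 5 heavy atoms (3 carbon, 1 nitrogen, 1 sulfur; no ring) in place of a group of 6 heavy atoms (4 carbon, 1 nitrogen, 1 sulfur; no ring), on an amine nitrogen. No readable step bears on this change, so for compound 3 a step that the limit leaves unreadable from compound 2 to compound 3 is expected, most likely again a limit. Compound 3 is estimated at 150 mg/kg, range 40 mg/kg to 600 mg/kg.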

Compound 3, dose for half-maximal effect: 37.2 mg/kg
The estimate for compound 3 lay 4.0-fold (0.61 log units) above the measured number, outside the stated range (below it).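

In this assay, the group of 5 heavy atoms in place of the group of 6 heavy atoms, on an amine nitrogen, gives an at least 2.6-fold lower number from compound 2 to compound 3 (0.42 log units; beyond the scatter), so a change at this position can bring a measurable number into the series. The comparison with the core of compound 1 gives an at least 2.6-fold lower number from compound 1 to compound 3 (0.42 log units; beyond the scatter), while the step between the other two compounds cannot be read. Both readable steps have only a lower bound on their size: the limit of > 100 mg/kg in this assay, at which 2 of the 3 values shown sit.

The compounds shown leave open whether a phenyl group or a longer chain on that amine nitrogen would lower the number further. Also open, on these data alone, is whether an oxygen in place of the sulfur would keep the value of compound 3.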